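Halogen removal in a benzyl-viologen indole series

A few compounds are considered here, and "the series" means these few. Any claim that something is new, unique, unknown or untested is made for them only; others in the source may bear on it.

Measured compounds:
- compound 1, `FC(F)(F)c1nc2c(-[n+]3cc[n+](Cc4ccccc4)cc3)cccc2[nH]1` — 2.9 nM
- compound 2, `Clc1ccc2[nH]ccc2c1-[n+]1cc[n+](Cc2ccccc2)cc1` — 1.7 nM
- compound 3, `Brc1ccc(-[n+]2cc[n+](Cc3ccccc3)cc2)c2cc[nH]c12` — 2.6 nM

In an assay on isolated protein for binding affinity to D(4) dopamine receptor (Homo sapiens) (a lower number here means a stronger inhibitor, a higher number a weaker inhibitor), compound 3 gives 2.6 nM. Compound 1 gives 2.9 nM and compound 2 gives 1.7 nM in this assay; both gaps to compound 3 lie within the usual scatter, so the three numbers do not separate from one another.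

Compound 4, `c1ccc(C[n+]2cc[n+](-c3cccc4[nH]ccc34)cc2)cc1`, is not yet measured. It differs from compound 3 by hydrogen in place of bromo on an aromatic carbon. Within the data shown here, no measured pair in this set isolates a halogen-to-hydrogen exchange, so the size of this step cannot be read from neighbours. The three measured compounds carry different groups on their cores and still land close together, which argues against a large shift in either direction.

Compound 4 is expected to lose a modest amount, with a step of a 1.9-fold higher number from compound 3 to compound 4 (0.28 log units; within the scatter) in this assay. The estimate for compound 4 is 5 nM, with a range from 1.5 nM to 20 nM.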

Compound 4, inhibition constant: 14.7 nM
For compound 4 the middle estimate is 2.9-fold (0.47 log units) below the measured one; measured number inside the range.
By their numbers in this assay, from the lowest: compounds 2, 3 and 1 (each within the scatter of the next); then compound 4.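

Replacing bromo with hydrogen on the aromatic carbon para to a large group gives a 5.7-fold higher number from compound 3 to compound 4 (0.75 log units; beyond the scatter) in this assay, so this position is not indifferent to its substituent, as the close values of the first three compounds might have suggested. Replacing chloro with hydrogen points the same way, with an 8.6-fold higher number from compound 2 to compound 4 (0.94 log units; beyond the scatter), so in both pairs the compound without the halogen has the higher number. No supporting data bear on why the hydrogen compound falls away.

On these data alone, whether any group larger than hydrogen would restore the lower numbers or only a halogen does remains open, and a methyl, a methoxy or a nitrile on this carbon would test that. Compound 1 carries trifluoromethyl rather than a halogen on its core, and fluoro and iodo are also absent, so the link to halogens rests on two pairs.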